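The source may hold more compounds than are shown below. What is called first, only, known or untested is meant among the compounds shown, and "the series" means these compounds.

In a functional assay on Malme-3M cells (Homo sapiens) for antiproliferative activity, read by sulforhodamine B assay, with a stated time of 48 h (a lower number here means a stronger inhibitor, a higher number a weaker inhibitor), compound 1 `COc1ccc(C(=O)Nc2cccc(-c3ccnc4c(NC(C)=O)cccc34)c2)cc1OC` gives 2000 nM and compound 2 `CC(=O)Nc1cccc2c(-c3cccc(NC(=O)c4ccc(Cl)c(C(F)(F)F)c4)c3)ccnc12` gives 2700 nM. Compound 2 stands as the higher of the two numbers, with compound 1 nearest to it, and the step of a 1.4-fold higher number from compound 1 to compound 2 (0.13 log units; within the scatter) lies within the scatter. Compound 3 `CC(=O)Nc1cccc2c(-c3cccc(NC(=O)c4ccc5c(c4)OCCO5)c3)ccnc12` differs from compound 2 by 2,3-dihydro-1,4-benzodioxin-6-yl in place of 4-chloro-3-(trifluoromethyl)phenyl on a carbonyl carbon. Among the compounds with values here, the only measured step bearing on this swap on the carbonyl carbon, a 1.4-fold higher number from compound 1 to compound 2 (0.13 log units; within the scatter), stayed within the scatter, so no step beyond the scatter is expected in this assay, the expected step being a 1.2-fold lower number from compound 2 to compound 3 (0.07 log units; within the scatter). Compound 3 is estimated at 2300 nM, with a range of 1000 nM to 5000 nM.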

Compound 3, half-maximal inhibitory concentration: > 20000 nM
Compound 3 ended at the assay's limit; the forecaster's own chance of this, stated with the estimate: 5%; middle value at least 8.6-fold (0.93 log units) from the limit.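

On the carbonyl carbon, the group is not freely exchangeable in this assay: 2,3-dihydro-1,4-benzodioxin-6-yl gives an at least 7.4-fold higher number from compound 2 to compound 3 (0.86 log units; beyond the scatter) and an at least 10-fold higher number from compound 1 to compound 3 (1.00 log units; beyond the scatter), whereas the earlier swap stayed within the scatter. For compound 3, > 20000 nM is a limit of the assay, not a number. Oxygen in the group does not by itself set the outcome, since 3,4-dimethoxyphenyl in compound 1 and the ring of compound 3 both carry it.

Still open, going by these compounds, is how a phenyl bearing a single methoxy group or an amine would read here. Also open, on these data alone, is whether a longer chain in place of the ring oxygens would stay near compound 1.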